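The source may hold more compounds than are shown below. What is called first, only, known or untested is meant among the compounds shown, and "the series" means these compounds.

Working notes on the series, read in a functional assay on HeLa cells (Homo sapiens) for inhibition, read by sulforhodamine B assay; a lower number here means a stronger inhibitor, a higher number a weaker inhibitor. Among the measured compounds shown here, compound 1 `Cc1ccc(NC2=CC(=O)c3c(nc4n3[C@H]3OC[C@@H](O)[C@H]3OC4)C2=O)cc1C` gives 4320 nM, the only measured number so far. Compound 2 `O=C1C=C(NC2CCCCC2)C(=O)c2c1nc1n2[C@H]2OC[C@@H](O)[C@H]2OC1` gives > 16000 nM, which is a limit of the assay. Compound 3 `COc1ccc(NC2=CC(=O)c3c(nc4n3[C@H]3OC[C@@H](O)[C@H]3OC4)C2=O)cc1` gives > 8000 nM, which is also a limit. Compound 2 therefore offers only a limit as a starting point, and it is not the only limit in the set.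

Next comes compound 4 `O=C1C=C(Nc2ccc(Br)cc2)C(=O)c2c1nc1n2[C@H]2OC[C@@H](O)[C@H]2OC1`: 4-bromophenyl in place of cyclohexyl on an amine nitrogen. In words, this places 4-bromophenyl in place of cyclohexyl on an amine nitrogen. For the measured compounds named here, no measured step makes this exact change. The closest one exchanges one aryl group for another, 4-methoxyphenyl in place of 3,4-dimethylphenyl, and gives an at least 1.8-fold higher number from compound 1 to compound 3 (0.26 log units; that floor lies within the scatter). That step gives only a floor, so it fixes no size for the change here.

The expectation rests mainly on compound 1 at 4320 nM, which shows that an aryl amine can give a number in this assay. Compound 3 goes against any such rule, since it too is an aryl amine and has only a limit. A moderate move to a lower number is expected, with a real chance of no measurable gain. The expected size is an at least 2.6-fold lower number from compound 2 to compound 4 (0.42 log units; beyond the scatter). For compound 4 the estimated value is 6000 nM, with an expected range of 2000 nM to 16000 nM.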

Compound 4, half-maximal inhibitory concentration: 3830 nM
Compound 4: middle estimate off by 1.6-fold (0.19 log units), on the high side; measured number inside the range.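

Among the compounds shown here, on the amine nitrogen, the exchange of cyclohexyl for 4-bromophenyl gives a step in this assay that lies beyond the scatter, which the earlier compounds did not provide: an at least 4.1-fold lower number from compound 2 to compound 4 (0.62 log units; beyond the scatter). Going by these compounds, the true size of this step stays unknown, and the figure is only a floor, because compound 2 stands at a limit of the assay: the limit of > 16000 nM in this assay, at which 1 of the 4 values shown sits. Compound 3, an aryl amine like compound 4, also stands at a limit of the assay, so the step does not show that every aryl group on this nitrogen gives a measured number: the limit of > 8000 nM in this assay, at which 1 of the 4 values shown sits.

The compounds shown leave open how far the number of compound 2 really lies from that of compound 4, and whether the change follows the aromatic ring itself or the bromine on it. A plain phenyl, a 4-chlorophenyl or a benzyl group on the same amine nitrogen would bear on that question, and a longer alkyl chain there would test whether cyclohexyl's limit extends to other non-aromatic groups.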